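Ring hydroxy step from compound 1 to compound 4

A few compounds are considered here, and "the series" means these few. Any claim that something is new, unique, unknown or untested is made for them only; others in the source may bear on it.

Among the compounds with values here, in a toxicity assay on cells (Fibroblast, Homo sapiens) for cytotoxicity (on this read-out higher numbers stand for weaker inhibition and lower numbers for stronger inhibition), compound 1 (`CC(/C=C/C1=CCCCC1(C)C)=C\C=C\C(C)=C\COC(=O)c1ccccc1O`) gives 150000 nM, the highest of the three numbers measured so far and therefore the weakest inhibition. Compound 2 (`CC(/C=C/C1=CCCCC1(C)C)=C\C=C\C(C)=C\COC(=O)c1c(O)cccc1O`) gives 14000 nM and compound 3 (`COc1cccc(C(=O)OC/C=C(C)/C=C/C=C(C)/C=C/C2=CCCCC2(C)C)c1O`) gives 27000 nM. These two stand within the scatter of each other (a 1.9-fold higher number from compound 2 to compound 3 (0.29 log units; within the scatter)).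

Compound 4 (`CC(/C=C/C1=CCCCC1(C)C)=C\C=C\C(C)=C\COC(=O)c1ccc(O)cc1O`) is not yet measured. Its structural change is hydroxy in place of hydrogen on an aromatic carbon, meta to a hydroxy group and para to a large group, so that 2-hydroxyphenyl becomes 2,4-dihydroxyphenyl.

Within the data shown here, two measured steps bear on this change. Adding a hydroxy gives a large step (an 11-fold lower number from compound 1 to compound 2 (1.03 log units; beyond the scatter)), and adding a methoxy gives a modest one (a 5.6-fold lower number from compound 1 to compound 3 (0.74 log units; beyond the scatter)). Both run toward lower numbers, but neither places the new group where compound 4 carries it, so only a modest step is expected (a 4.3-fold lower number from compound 1 to compound 4 (0.63 log units; beyond the scatter)). For compound 4 the estimated value is 35000 nM, with an expected range of 13000 nM to 90000 nM.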

Compound 4, half-maximal inhibitory concentration: 120000 nM
For compound 4 the middle estimate is 3.4-fold (0.54 log units) below the measured one; the measured number lies above the stated range.
By their numbers in this assay, from the lowest: compounds 2 and 3 (each within the scatter of the next); then compounds 4 and 1 (each within the scatter of the next).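

In this assay, hydroxy in place of hydrogen para to a large group gives no step beyond the scatter (a 1.3-fold lower number from compound 1 to compound 4 (0.10 log units; within the scatter)), so compound 4 goes against the lower numbers seen with compounds 2 and 3, and adding a group to the 2-hydroxyphenyl ring does not by itself lower the number. Placement matters in this set: 2,4-dihydroxyphenyl gives a higher number than 2,6-dihydroxyphenyl (an 8.6-fold higher number from compound 2 to compound 4 (0.93 log units; beyond the scatter)) and 2-hydroxy-3-methoxyphenyl (a 4.4-fold higher number from compound 3 to compound 4 (0.65 log units; beyond the scatter)). No available evidence explains this dependence on placement.

From the compounds shown here alone, whether methoxy at the position of the new hydroxy in compound 4 would give a number near that of compound 4 remains open. Also open, going by these compounds, is how an amine or a carboxylic acid would behave at that position.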